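The source may hold more compounds than are shown below. What is called first, only, known or untested is meant among the compounds shown, and "the series" means these compounds.

Compound 1, `C#CCN(C)Cc1cn(-c2cc(NC(=S)NCC)ncn2)cn1`, gives 1430 nM in an assay on isolated protein for inhibition of Amine oxidase [flavin-containing] B (Homo sapiens), read by fluorescence and Amplex Red, with a stated time of 15 min; a higher number here means a weaker inhibitor, a lower number a stronger inhibitor.
Compound 2, `C#CCN(CC)Cc1cn(-c2cc(NC(=S)NCC)ncn2)cn1`, sits at a limit of this assay, > 50000 nM.
Compound 3, `C#CCN(CCC)Cc1cn(-c2cc(NC(=S)NCC)ncn2)cn1`, also sits at a limit of this assay, > 50000 nM.

Compound 3 therefore has no number of its own in this assay, only a limit, and it shares that position with compound 2, as the limit of > 50000 nM in this assay, at which 2 of the 3 values shown sit, shows. Against this background stands compound 4, `C#CCN(Cc1ccccc1)Cc1cn(-c2cc(NC(=S)NCC)ncn2)cn1`, which differs from compound 3 by phenyl in place of ethyl on a saturated chain carbon bound to an amine nitrogen.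

Within the data shown here, two measured steps bear on this kind of change, both growing the group on the saturated chain carbon bound to the amine nitrogen. The step of an at least 34-fold higher number from compound 1 to compound 2 (1.54 log units; beyond the scatter) and the step of an at least 34-fold higher number from compound 1 to compound 3 (1.54 log units; beyond the scatter) each moved a measurable inhibitor to a limit. The step that the two limits leave unreadable from compound 2 to compound 3, between two limits, cannot be read. Every enlargement seen so far has led to the limit, and compound 4 enlarges the group again, so compound 4 is expected to remain at or beyond that limit rather than return to a measurable number. The estimate for compound 4 is 60000 nM, with a range from 10000 nM to 300000 nM. This estimate means a step that the limit leaves unreadable from compound 3 to compound 4 that is expected to be unreadable in the same way.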

Compound 4, half-maximal inhibitory concentration: > 50000 nM
Compound 4 gave a limit, no number; the forecaster's own chance of this, stated with the estimate: 75%; the middle value lies beyond the limit too.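

Compound 4 sits at a limit in this assay, > 50000 nM, and so has no number of its own. Ethyl and methyl had already left open the possibility that only open chains fail on the saturated chain carbon bound to an amine nitrogen, but phenyl brings a six-membered aromatic ring to that place and still gives no measurable number, with an at least 34-fold higher number from compound 1 to compound 4 (1.54 log units; beyond the scatter). The steps among compound 2, compound 3 and compound 4 cannot be read, so no order can be given among these three, and the firm finding is the position they share: the limit of > 50000 nM in this assay, at which 3 of the 4 values shown sit.

Compound 1 remains the only one of the four with a number, so the compounds shown leave open how far beyond the limit the other three lie and whether any group larger than hydrogen on this carbon can be tolerated. They also leave open whether a group of another kind on this carbon, such as a hydroxyl, an amine or a carboxylic acid, would bring back a measurable number.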